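From 4-hydroxy-2-methylphenyl to 4-ethylphenyl on the shared core

A few compounds are considered here, and "the series" means these few. Any claim that something is new, unique, unknown or untested is made for them only; others in the source may bear on it.

In a functional assay on RPMI-8226 cells (Homo sapiens) for inhibition, read by sulforhodamine B assay, with a stated time of 48 h (a higher number here means a weaker inhibitor of growth, a lower number a stronger inhibitor of growth), compound 1 `Cc1ccc(C2=NN(c3ccc(S(C)(=O)=O)cc3)C(=O)CC2)cc1` gives 2780 nM, and compound 2 `Cc1cc(O)ccc1C1=NN(c2ccc(S(C)(=O)=O)cc2)C(=O)CC1` gives 25600 nM. Going by the values given here, compound 2 therefore holds the higher of only two numbers, making it the weaker growth inhibitor of the pair.

The next compound is compound 3 `CCc1ccc(C2=NN(c3ccc(S(C)(=O)=O)cc3)C(=O)CC2)cc1`, which carries 4-ethylphenyl in place of 4-hydroxy-2-methylphenyl on a carbon with a double bond to nitrogen.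

Among the compounds with values here, one measured step bears on this change: a 9.2-fold higher number from compound 1 to compound 2 (0.96 log units; beyond the scatter). That modest step, beyond the scatter, came with 4-hydroxy-2-methylphenyl replacing 4-methylphenyl at the same carbon. Compound 3 gives up the group that entered in that step, so a move back toward the level of compound 1 at 2780 nM is expected in this assay. Within the data shown here, no measured compound yet shows how 4-ethylphenyl itself behaves, so the range is kept wide. The expected change, toward a lower number and of similar size to the measured step, is a 10-fold lower number from compound 2 to compound 3 (1.01 log units; beyond the scatter). Compound 3 is estimated at 2500 nM, with an expected range of 800 nM to 8000 nM.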

Compound 3, concentration for 50% growth inhibition: 420 nM
Estimate against measurement, compound 3: 6.0-fold (0.77 log units) above; measured number outside the range, below it.
By their numbers in this assay, from the lowest: compound 3; then compound 1; then compound 2.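

In this assay, going by these compounds alone, the group on the carbon with a double bond to nitrogen can now be seen to move the number in both directions, where the earlier compounds showed only a rise. Compound 3 is the strongest inhibitor of growth of the three, and the exchange of 4-hydroxy-2-methylphenyl for 4-ethylphenyl spans a large step (a 61-fold lower number from compound 2 to compound 3 (1.78 log units; beyond the scatter)), while the single added methyl on the saturated chain carbon gives a modest one beyond the scatter (a 6.6-fold lower number from compound 1 to compound 3 (0.82 log units; beyond the scatter)), so even this small extension of the 4-methylphenyl group of compound 1 is enough to register in this assay. Nothing available here explains why 4-ethylphenyl outperforms 4-methylphenyl at this position.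

On these data alone, whether the fall continues with a longer chain such as propyl or butyl, or reverses with a branched group such as isopropyl, remains open, as does the effect of an amine at the same place. The contributions of the hydroxy and the methyl within 4-hydroxy-2-methylphenyl also cannot be separated from the compounds shown.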